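Will a 3,4,5-Trimethoxyphenyl Swap Shift Cytotoxicity?

The source may report more compounds than this note shows. Statements on the series, on what has been measured and on what is new or still open speak of the compounds shown alone.

In a functional assay on A549 cells (Homo sapiens) for cytotoxicity, read by MTT assay, with a stated time of 72 h (on this read-out higher numbers stand for weaker inhibition and lower numbers for stronger inhibition), compound 1 `COc1cc2ncnc(Nc3ccc(F)c(Cl)c3)c2cc1NC(=O)N/N=C/c1ccc(F)cc1` gives 26600 nM, compound 2 `COc1cc2ncnc(Nc3ccc(F)c(Cl)c3)c2cc1NC(=O)N/N=C/c1cccc(Br)c1` gives 28100 nM, and compound 3 `COc1cc2ncnc(Nc3ccc(F)c(Cl)c3)c2cc1NC(=O)N/N=C/c1cccc(Cl)c1Cl` gives 35300 nM, so compound 3 cannot be told apart from the other two. Compound 4 `COc1cc2ncnc(Nc3ccc(F)c(Cl)c3)c2cc1NC(=O)N/N=C/c1cc(OC)c(OC)c(OC)c1` differs from compound 3 at one place: 3,4,5-trimethoxyphenyl in place of 2,3-dichlorophenyl on a carbon with a double bond to nitrogen. Three measured swaps at that same place bear on this change: a 1.1-fold higher number from compound 1 to compound 2 (0.02 log units; within the scatter), a 1.3-fold higher number from compound 1 to compound 3 (0.12 log units; within the scatter) and a 1.3-fold higher number from compound 2 to compound 3 (0.10 log units; within the scatter). All three lie within the scatter. For the measured compounds named here, no measured compound carries the 3,4,5-trimethoxyphenyl group, so the range stays wide. The expected 1.3-fold lower number from compound 3 to compound 4 (0.10 log units; within the scatter) is no larger than the scatter. For compound 4, the estimated value is 28000 nM, with a range of 12000 nM to 65000 nM.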

Compound 4, half-maximal inhibitory concentration: 32100 nM
Compound 4: the middle estimate sits 1.1-fold (0.06 log units) below what was measured; measured number inside the range.
By their numbers in this assay, from the lowest: compounds 1, 2, 4 and 3 (each within the scatter of the next).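

Swapping in the 3,4,5-trimethoxyphenyl group adds hydrogen-bond acceptors, which the 2,3-dichlorophenyl group lacks, yet this assay shows a 1.1-fold lower number from compound 3 to compound 4 (0.04 log units; within the scatter) and a 1.1-fold higher number from compound 2 to compound 4 (0.06 log units; within the scatter) and a 1.2-fold higher number from compound 1 to compound 4 (0.08 log units; within the scatter) with all three steps within the scatter. So the aromatic ring on the carbon with a double bond to nitrogen can carry methoxy groups as well as halogens with no readable change among these four compounds. Nothing available here explains this.

Still open, going by these compounds, is whether an amine or a carboxylic acid on that ring, or a longer chain in place of the ring, would shift the number.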